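The source may report more compounds than this note shows. Statements on the series, on what has been measured and on what is new or still open speak of the compounds shown alone.

Series notes. In an assay on isolated protein for displacement of a labelled ligand from 5-hydroxytryptamine receptor 6 (Homo sapiens), read by scintillation counting, with a stated time of 1 h (on this read-out lower numbers stand for stronger inhibition and higher numbers for weaker inhibition), compound 3 `CN(C)c1ccc2c(ccn2S(=O)(=O)c2ccccc2)c1` gives 82 nM, the lowest number of the three measured; compound 1 `COc1ccc2c(ccn2S(=O)(=O)c2ccccc2)c1` gives 127 nM, a gap within the scatter (a 1.5-fold lower number from compound 1 to compound 3 (0.19 log units; within the scatter)), while compound 2 `CC(=O)N1CCN(c2ccc3c(ccn3S(=O)(=O)c3ccccc3)c2)CC1` gives 4850 nM and stands far off (a 59-fold lower number from compound 2 to compound 3 (1.77 log units; beyond the scatter)). Compound 4 `O=S(=O)(c1ccccc1)n1ccc2cc(-c3ccncc3)ccc21` carries pyridin-4-yl in place of dimethylamino on an aromatic carbon. Among the measured compounds shown here, no measured step exchanges the group on that carbon for an aromatic ring; the only step that brings in a ring at this position, a 38-fold higher number from compound 1 to compound 2 (1.58 log units; beyond the scatter), is large and raises the number, whereas the small exchange in a 1.5-fold lower number from compound 1 to compound 3 (0.19 log units; within the scatter) barely moves it. A moderate rise is therefore expected for compound 4, as a 3.7-fold higher number from compound 3 to compound 4 (0.56 log units; beyond the scatter). Compound 4 is estimated at 300 nM in this assay, with a range from 60 nM to 1500 nM.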

Compound 4, inhibition constant: 409 nM
For compound 4 the middle estimate is 1.4-fold (0.13 log units) below the measured one; low and high end bracket the measured number.
By their numbers in this assay, from the lowest: compounds 3 and 1 (each within the scatter of the next); then compound 4; then compound 2.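

In this assay an aromatic ring on this carbon raises the number only modestly, whether it replaces dimethylamino (a 5.0-fold higher number from compound 3 to compound 4 (0.70 log units; beyond the scatter)) or methoxy (a 3.2-fold higher number from compound 1 to compound 4 (0.51 log units; beyond the scatter)). The pyridin-4-yl group also stands well clear of 4-acetylpiperazin-1-yl (a 12-fold lower number from compound 2 to compound 4 (1.07 log units; beyond the scatter)), so the large rise seen with that group does not follow for every six-membered ring here. Nothing available explains these differences.

Open, going by these compounds, is whether phenyl or pyridin-3-yl would match pyridin-4-yl. Also open, on these data alone, is how an unacetylated piperazin-1-yl would compare with its 4-acetyl counterpart.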